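Moving the Hydroxyl from 3-Hydroxyphenyl to 4-Hydroxyphenyl

The compounds below may be only part of what the source reports. "The series", "measured", "known", "first", "only" and "open" are said of these compounds alone.

In a functional assay on HCT-15 cells (Homo sapiens) for cytotoxicity, read by CCK-8 assay and cell counting, with a stated time of 2 days (on this read-out lower numbers stand for stronger inhibition and higher numbers for weaker inhibition), compound 2 (`Oc1cccc(-c2cc(-c3ccsc3)nc(-c3cccc(Cl)c3)c2)c1`) stands at 2510 nM and holds the lower of the two numbers, while compound 1 (`Oc1ccc(-c2cc(-c3cccnc3)nc(-c3cccc(Cl)c3)c2)cc1`) reads 21300 nM on the same scale. Compound 3 (`Oc1ccc(-c2cc(-c3ccsc3)nc(-c3cccc(Cl)c3)c2)cc1`) differs from compound 2 by one change (4-hydroxyphenyl in place of 3-hydroxyphenyl on an aromatic carbon), with 4-hydroxyphenyl in place of 3-hydroxyphenyl on an aromatic carbon. Among the measured compounds shown here, no measured pair isolates this change. Compound 1 also carries 4-hydroxyphenyl, though it differs elsewhere too, so a moderate upward step beyond the scatter is expected in this assay. The estimated move is a 2.4-fold higher number from compound 2 to compound 3 (0.38 log units; beyond the scatter) toward weaker inhibition. Compound 3 is estimated at 6000 nM (2000 nM to 20000 nM).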

Compound 3, half-maximal inhibitory concentration: 5760 nM
Beside the measured number, compound 3's estimate is 1.0-fold (0.02 log units) above it; low and high end bracket the measured number.
By their numbers in this assay, from the lowest: compound 2; then compound 3; then compound 1.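

In this assay the swap of 3-hydroxyphenyl for 4-hydroxyphenyl gives a 2.3-fold higher number from compound 2 to compound 3 (0.36 log units; beyond the scatter) and shows that, at this place opposite the ring nitrogen, the location of the hydroxyl alone shifts the number modestly toward weaker inhibition. With 4-hydroxyphenyl held fixed, thiophen-3-yl in place of pyridin-3-yl gives a 3.7-fold lower number from compound 1 to compound 3 (0.57 log units; beyond the scatter) and so shifts the number modestly toward stronger inhibition. No measurement here explains either step.

Open, as far as these compounds go, is how a methoxy group or an amine in place of the hydroxyl would read at this place.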